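A few compounds are considered here, and "the series" means these few. Any claim that something is new, unique, unknown or untested is made for them only; others in the source may bear on it.

Working notes on the series, in an ADME assay on the whole organism (Mus musculus, strain CD1) for pharmacokinetics, at a dose of 10 mg/kg by the oral route; a higher number here means more compound in the circulation at the dose given, a lower number less compound in the circulation. Compound 1 `CN1CCC(Oc2ccc(N3C(=S)N(c4cnc(C#N)c(C(F)(F)F)c4)C(=O)C34CCC4)cn2)CC1` gives 10900 ng.h/mL, compound 2 `Cc1cc(N2C(=O)C3(CCC3)N(c3ccc(OC4CCNCC4)nc3)C2=S)cnc1C#N` gives 7800 ng.h/mL and compound 3 `N#Cc1ncc(N2C(=O)C3(CCC3)N(c3ccc(OC4CCNCC4)cc3)C2=S)cc1Cl` gives 4600 ng.h/mL. Compound 2 stands within the scatter of both of the other two compounds, so its value cannot be separated from either of theirs.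

The next compound is compound 4 `N#Cc1ncc(N2C(=O)C3(CCC3)N(c3ccc(OC4CCNCC4)nc3)C2=S)cc1C(F)(F)F`, which is still to be measured in this assay. It follows from compound 2 by one change: trifluoromethyl in place of methyl on an aromatic carbon. This puts trifluoromethyl in place of methyl on an aromatic carbon, ortho to a cyano group.

Within the data shown here, no two measured compounds differ in one place only, so the size of this change has not been measured directly. The available evidence is indirect. Compound 1 also carries trifluoromethyl and gives 10900 ng.h/mL, which lies within the scatter of the value for compound 2 and gives no sign of a large loss of exposure. On this limited basis, no shift beyond the scatter is expected, and any movement is expected to be slightly upward. The estimated change is a 1.1-fold higher number from compound 2 to compound 4 (0.04 log units; within the scatter), which is expected to stay within the scatter. For compound 4 the expected value is 8500 ng.h/mL, with an estimated range of 3500 ng.h/mL to 20000 ng.h/mL.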

Compound 4, area under the concentration-time curve: 4900 ng.h/mL
Beside the measured number, compound 4's estimate is 1.7-fold (0.24 log units) above it; measured number inside the range.
By their numbers in this assay, from the lowest: compounds 3, 4, 2 and 1 (each within the scatter of the next, the first and the last beyond it).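

In this assay, trifluoromethyl in place of methyl on an aromatic carbon, ortho to a cyano group, now has a direct reading: a 1.6-fold lower number from compound 2 to compound 4 (0.20 log units; within the scatter) and so this exchange is not separated from no change at this place on the ring. With trifluoromethyl held constant, hydrogen in place of methyl on an amine nitrogen in a ring gives a 2.2-fold lower number from compound 1 to compound 4 (0.35 log units; beyond the scatter) and this modest step is the only one read so far that lies beyond the scatter. The trifluoromethyl shared by compound 1 and compound 4 therefore does not ensure the number seen for compound 1, and the two steps together point to the amine nitrogen as the more informative of the two places, within these compounds only.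

The compounds shown leave open how hydrogen, ethyl or methoxy would read at the aromatic carbon, and how a longer chain such as ethyl or propyl would read on the amine nitrogen. No measurement shown bears on the cause of either step.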